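Bromine for chlorine on two related isatin-type cores

This account rests on a few compounds, and the source may have more. Where it says the series, first, only, none or still open, it means among the compounds named here.

Compound 1 `O=C1C(=O)N(CN2CCN(c3ccnc4cc(Cl)ccc34)CC2)c2cccc(Cl)c21`: 37800 nM
Compound 2 `O=C1C(=O)N(CN2CCN(c3ccnc4cc(Cl)ccc34)CC2)c2cccc(Br)c21`: 15900 nM
Compound 3 `NC(=S)N/N=C1/C(=O)N(CN2CCN(c3ccnc4cc(C(F)(F)F)ccc34)CC2)c2cc(Cl)ccc21`: 11000 nM

These three compounds were tested in a functional assay on MDA-MB-468 cells (Homo sapiens) for cytotoxicity, read by sulforhodamine B assay, with a stated time of 48 h; on this read-out lower numbers stand for stronger inhibition of growth and higher numbers for weaker inhibition of growth. Compound 2 differs from compound 1 by bromo in place of chloro on an aromatic carbon, and this change gave a 2.4-fold lower number from compound 1 to compound 2 (0.38 log units; beyond the scatter). Compound 3 has a different core; how the two cores differ is not broken down here. Compound 4 `NC(=S)N/N=C1/C(=O)N(CN2CCN(c3ccnc4cc(C(F)(F)F)ccc34)CC2)c2cc(Br)ccc21` is not yet measured; it differs from compound 3 by bromo in place of chloro on an aromatic carbon. This is the same kind of change as from compound 1 to compound 2, but the place differs: in compound 1 the carbon is ortho to a fused ring and meta to a fused ring, in compound 3 it is meta to a fused ring and para to a fused ring. Compound 4 is expected to show a step of a 1.8-fold lower number from compound 3 to compound 4 (0.26 log units; within the scatter), a little smaller than the earlier one because the place differs and because of a 2.4-fold lower number from compound 1 to compound 2 (0.38 log units; beyond the scatter) alone as precedent. Compound 4 is estimated at 6000 nM, likely between 3000 nM and 12000 nM.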

Compound 4, concentration for 50% growth inhibition: 39600 nM
Compound 4: the middle estimate sits 6.6-fold (0.82 log units) below what was measured; measured number outside the range, above it.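

In this assay, bromo in place of chloro on an aromatic carbon gave a 3.6-fold higher number from compound 3 to compound 4 (0.56 log units; beyond the scatter), the opposite direction to the earlier step. The effect of this change therefore did not carry over from one core to the other: the same change on two cores in this assay, a 2.4-fold lower number (0.38 log units; beyond the scatter) from compound 1 to compound 2 and a 3.6-fold higher number (0.56 log units; beyond the scatter) from compound 3 to compound 4, 8.6-fold (0.93 log units) apart, beyond the scatter of two such steps. The two pairs differ both in the core and in where the halogen sits, and the data do not separate these two, so no cause can be named, and a single pair on each core sets no usual direction for the change.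

The compounds shown leave open whether the reversal would remain with the halogen at the same place on both cores. They also leave open how a fluoro, a methyl or an amine at this place would compare with chloro and bromo.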